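Bromo for chloro on the 4-chlorophenoxy end

The compounds below may be only part of what the source reports. "The series", "measured", "known", "first", "only" and "open" are said of these compounds alone.

In a functional assay (aorta) with Oryctolagus cuniculus as the target (on this read-out lower numbers stand for tighter binding and higher numbers for weaker binding), compound 1 `COc1cc(C#N)ccc1OCCCN1CCC(C(c2ccc(F)cc2)c2ccc(F)cc2)CC1` gives 2 nM. For the measured compounds named here, compound 2 `Fc1ccc(C(c2ccc(F)cc2)C2CCN(CCCOc3ccc(Cl)cc3)CC2)cc1` gives 2 nM, level with compound 1, which is its only measured neighbour. The next entry is compound 3 `Fc1ccc(C(c2ccc(F)cc2)C2CCN(CCCOc3ccc(Br)cc3)CC2)cc1`, with bromo in place of chloro on an aromatic carbon, para to a large group: bromo in place of chloro on an aromatic carbon.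

Going by the values given here, one measured step bears on this change: no change at the digits printed from compound 1 to compound 2 (within the scatter). That step swapped the whole aryl group on the oxygen, and the value held. Among the compounds with values here, no measured pair covers a swap of one halogen for another, so this evidence is indirect and thin. No step beyond the scatter is expected in this assay, and no direction is favoured. The estimated step is no change at the digits printed from compound 2 to compound 3 (within the scatter). For compound 3 the expected value is 2 nM, with an estimated range of 0.8 nM to 5 nM.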

Compound 3, dissociation constant: 1.59 nM
Compound 3: the middle estimate sits 1.3-fold (0.10 log units) above what was measured; the measured number falls inside the stated range.
By their numbers in this assay, from the lowest: compounds 3, 1 and 2 (each within the scatter of the next).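

In this assay the halogen swap itself gives a 1.3-fold lower number from compound 2 to compound 3 (0.10 log units; within the scatter) and so separates chloro from bromo on this aromatic carbon, para to a large group, no more than repeated measurements would. The wider change on the oxygen, from 4-cyano-2-methoxyphenyl to 4-bromophenyl, gives a 1.3-fold lower number from compound 1 to compound 3 (0.10 log units; within the scatter) and shows that the level of compound 2 also holds with bromo in compound 3. No supporting data accompany these values to explain why the read-out stays level.

Whether hydrogen, methyl, trifluoromethyl or an amine at this place would hold the same level stays open, since only chloro and bromo are shown there. Also open, as far as these compounds go, is whether a longer chain to the oxygen, or other groups in place of the two fluoro groups, would move the value beyond the scatter.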